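The source may report more compounds than this note shows. Statements on the series, on what has been measured and on what is new or still open speak of the compounds shown alone.

Measured compounds:
Compound 1 `C=C1C(=O)O[C@@H]2[C@@H]3[C@@]4(C=C[C@@]3(C)[C@]3(C4)C(=O)O[C@@H]4[C@H]5C(C)=CC[C@H]5[C@](C)(O)C[C@H](O)[C@H]43)[C@](C)(O)CC[C@@H]12` — in a functional assay on CNE-2 cells (Homo sapiens) for cytotoxicity, read by MTT assay, with a stated time of 48 h (a higher number here means a weaker inhibitor, a lower number a stronger inhibitor), compound 1 gives only a limit, > 10000 nM.
Compound 2 `C=C1C(=O)O[C@H]2[C@H]1[C@@H](OC(=O)/C(C)=C/C)C[C@@](C)(O)[C@]13C=C[C@](C)([C@H]21)[C@]1(C3)C(=O)O[C@@H]2[C@H]3C(C)=CC[C@H]3[C@](C)(O)C[C@H](O)[C@H]21` — in this assay compound 2 gives only a limit as well, > 10000 nM.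
Compound 3 `C=C1C(=O)O[C@H]2[C@H]1[C@@H](OC(=O)/C(C)=C/C)C[C@@](C)(O)[C@]13C=C[C@](C)([C@H]21)[C@]1(C3)C(=O)O[C@@H]2[C@H]3C(C)=CC[C@H]3[C@](C)(O)C[C@H](OC(=O)/C(C)=C/C)[C@H]21` — in this assay compound 3 gives 6000 nM.

For the measured compounds named here, compound 3 thus holds the only number in the set; the two other values sit at the limit of > 10000 nM in this assay, at which 2 of the 3 values shown sit. The step that the two limits leave unreadable from compound 1 to compound 2 cannot be read, both of its ends being limits. Going by the values given here, the step of an at least 1.6-fold lower number from compound 2 to compound 3 (0.22 log units; that floor lies within the scatter) is the one readable step, and its floor lies within the scatter.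

Compound 4 `C=C1C(=O)O[C@@H]2[C@@H]3[C@@]4(C=C[C@@]3(C)[C@]3(C4)C(=O)O[C@@H]4[C@H]5C(C)=CC[C@H]5[C@](C)(O)C[C@H](OC(=O)/C(C)=C/C)[C@H]43)[C@](C)(O)CC[C@@H]12` is not yet measured. It differs from compound 3 as follows: hydrogen in place of ((1-methylprop-1-en-1-yl)carbonyl)oxy on a saturated ring carbon. This undoes on compound 3 the kind of change that takes compound 1 to compound 2, for which a step that the two limits leave unreadable from compound 1 to compound 2 gives no readable size, so compound 4 stands as compound 1 carrying the (1-methylprop-1-en-1-yl)carbonyl that compound 2 gains on the way to compound 3. Among the compounds with values here, no measured step fixes the direction here. The estimate for compound 4 is 9000 nM, between 4000 nM and 25000 nM, with the limit a real possibility. The step this implies, a 1.5-fold higher number from compound 3 to compound 4 (0.18 log units; within the scatter), is expected to stay within the scatter.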

Compound 4, half-maximal inhibitory concentration: > 10000 nM
Compound 4: a limit, no number; the forecaster's own chance of this, stated with the estimate: 45%; middle value at least 1.1-fold (0.04 log units) from the limit.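

In this assay, hydrogen in place of ((1-methylprop-1-en-1-yl)carbonyl)oxy on this saturated ring carbon of the seven-membered ring gives an at least 1.6-fold higher number from compound 3 to compound 4 (0.22 log units; that floor lies within the scatter). The value of compound 4 is a limit, > 10000 nM. Compound 2 and compound 4 each lack one of the two ester groups of compound 3 and both stand at the limit, so within these compounds a number appears only with both groups in place: the limit of > 10000 nM in this assay, at which 3 of the 4 values shown sit.

Steps with a limit at both ends, among them the one joining compound 1 and compound 4, cannot be read, so the spacing among compound 1, compound 2 and compound 4 stays open. Also open, on these data alone, is whether an acetyl ester, a longer acyl chain or an amine on this ring carbon would keep a number in this assay.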